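Swapping the fused ring in a urea cytotoxicity series

This account rests on a few compounds, and the source may have more. Where it says the series, first, only, none or still open, it means among the compounds named here.

Compound 2 `O=C(Nc1ccc(-n2ncc3c(F)cccc32)cc1)Nc1ccc(Cl)c(C(F)(F)F)c1` shows the highest number of the three measured compounds, at 29500 nM in a functional assay on HepG2 cells (Homo sapiens) for cytotoxicity, read by MTT assay, with a stated time of 72 h; on this read-out lower numbers stand for stronger inhibition and higher numbers for weaker inhibition. Compound 1 `O=C(Nc1ccc(-n2ncc3c(C(F)(F)F)cccc32)cc1)Nc1ccc(Cl)c(C(F)(F)F)c1` gives 8000 nM, and compound 3 `O=C(Nc1ccc(-n2ncc3c(C(F)(F)F)cccc32)cc1)Nc1ccc(C(F)(F)F)cc1` gives 1000 nM. Compound 4 `O=C(Nc1ccc(-n2ncc3cccnc32)cc1)Nc1ccc(Cl)c(C(F)(F)F)c1` differs from compound 2 by a group of 9 heavy atoms (6 carbon, 3 nitrogen; one five-membered aromatic ring with 2 hetero atoms, one six-membered aromatic ring with 1 hetero atom) in place of a group of 10 heavy atoms (7 carbon, 2 nitrogen, 1 fluorine; one five-membered aromatic ring with 2 hetero atoms, one six-membered aromatic ring of carbon only), on an aromatic carbon. Two measured steps are known: a 3.7-fold higher number from compound 1 to compound 2 (0.57 log units; beyond the scatter) and an 8.0-fold lower number from compound 1 to compound 3 (0.90 log units; beyond the scatter). Neither of them exchanges the fused ring itself, so they only set the scale of what one change has done in this set. Because the step of a 3.7-fold higher number from compound 1 to compound 2 (0.57 log units; beyond the scatter) was modest, removing that fluoro as part of the new ring is expected to give a modest step, a 1.6-fold lower number from compound 2 to compound 4 (0.21 log units; within the scatter), toward a lower number. Compound 4 is therefore expected near 18000 nM, within a range from 5000 nM to 60000 nM.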

Compound 4, half-maximal inhibitory concentration: > 32000 nM
Compound 4 ended at the assay's limit; the forecaster's own chance of this, stated with the estimate: 20%; middle value at least 1.7-fold (0.24 log units) from the limit.
By their numbers in this assay, from the lowest: compound 3; then compound 1; then compound 2. At a limit, above all of these: compound 4.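

In this assay compound 4 gives no number, only a limit of the assay: > 32000 nM. Exchanging the whole 4-fluoro-1H-indazol-1-yl group for the ring with a nitrogen in its six-membered part yields only a floor, an at least 1.0-fold higher number from compound 2 to compound 4 (0.03 log units; that floor lies within the scatter), so this change shows no gain at this position, and whether it costs anything cannot be read. The size of the step stays unknown, and this is the only compound at the limit: the limit of > 32000 nM in this assay, at which 1 of the 4 values shown sits.

As far as these compounds go, it remains open whether an amine or a methoxy group on the new ring would lower the number. Also open, from the compounds shown here alone, is how the new ring behaves with the 4-(trifluoromethyl)phenyl group of compound 3.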